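Swapping a Dichlorophenyl for a Methoxyphenyl on a Urea

This account rests on a few compounds, and the source may have more. Where it says the series, first, only, none or still open, it means among the compounds named here.

Measured so far:
- compound 1, `O=C(Nc1cccc(Cl)c1)Nc1nnc(Sc2ncnc3scc(-c4ccncc4)c23)s1`: 43900 nM
- compound 2, `O=C(Nc1ccc(Cl)c(Cl)c1)Nc1nnc(Sc2ncnc3scc(-c4ccncc4)c23)s1`: 14600 nM

Both compounds were tested in a functional assay on T47D cells (Homo sapiens) for antiproliferative activity, read by MTT assay, with a stated time of 48 h; a lower number here means a stronger inhibitor, a higher number a weaker inhibitor. Compound 1 gives 43900 nM, and compound 2 gives 14600 nM, the lowest of the two numbers recorded so far, with compound 1 as its nearest neighbour at a higher number. For the measured compounds named here, the only step recorded is a 3.0-fold lower number from compound 1 to compound 2 (0.48 log units; beyond the scatter), a modest gain that came from adding a second chlorine to the phenyl ring on the urea nitrogen.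

Compound 3, `COc1cccc(NC(=O)Nc2nnc(Sc3ncnc4scc(-c5ccncc5)c34)s2)c1`, has not yet been measured. Its change from compound 2 is 3-methoxyphenyl in place of 3,4-dichlorophenyl on an amide-type nitrogen. Going by the values given here, this undoes the gain seen going from compound 1 to compound 2 and at the same time replaces the remaining chlorine with a methoxy group, for which no step has been recorded. Compound 3 is therefore expected to lose the advantage of compound 2, giving an estimated step of a 3.1-fold higher number from compound 2 to compound 3 (0.49 log units; beyond the scatter). The expected value for compound 3 in this assay is 45000 nM, with a plausible range from 15000 nM to 150000 nM.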

Compound 3, half-maximal inhibitory concentration: 56900 nM
For compound 3 the middle estimate is 1.3-fold (0.10 log units) below the measured one, within the range that was stated.
By their numbers in this assay, from the lowest: compound 2; then compounds 1 and 3 (each within the scatter of the next).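

In this assay, 3-methoxyphenyl in place of 3,4-dichlorophenyl on the amide-type nitrogen gives a 3.9-fold higher number from compound 2 to compound 3 (0.59 log units; beyond the scatter) and so shows that the advantage of compound 2 is not shared by every substituted phenyl at this position. Methoxy in place of chloro on the aromatic carbon gives a 1.3-fold higher number from compound 1 to compound 3 (0.11 log units; within the scatter) and so leaves compound 1 and compound 3 indistinguishable here, with only the 3,4-dichlorophenyl group of compound 2 standing apart. No measurement offered here accounts for this difference.

The compounds shown leave open how an unsubstituted phenyl ring would compare with these three. They also leave open whether a fluoro, nitrile or carboxylic acid group on that ring would match compound 2 or fall with compound 1 and compound 3.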